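This account rests on a few compounds, and the source may have more. Where it says the series, first, only, none or still open, it means among the compounds named here.

Measured so far in a functional assay on the whole organism (strain albino) for inhibition, with Rattus norvegicus as the target, read by paw edema, with stated times of 30 min and 2 h, at a dose of 5 mg/kg by the oral route; a lower number here means less inhibition, a higher number more inhibition at the dose given (going by the name of the read-out): compound 1 `CCOC(=O)Cc1nc(N)n(C(=O)c2ccc(Cl)cc2)n1` gives 42.3%; compound 2 `CCOC(=O)Cc1nc(N)n(C(=O)c2ccc(Br)cc2)n1` gives 43%; compound 3 `CCOC(=O)Cc1n[nH]c(NC(=O)c2ccc(Cl)cc2)n1` gives 39.1%.

Compound 1 and compound 2 share one core, while compound 3 is built from the same atoms joined differently; the difference between the two cores is not broken down here. The change from compound 1 to compound 2 is bromo in place of chloro on an aromatic carbon and the step it made is a number 0.7 percentage points higher from compound 1 to compound 2 (within the scatter). Compound 3 stands within the scatter of both compound 1 and compound 2.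

Compound 4 `CCOC(=O)Cc1n[nH]c(NC(=O)c2ccc(Br)cc2)n1` is not yet measured. It differs from compound 3 by bromo in place of chloro on an aromatic carbon, the same change at the same place as that between compound 1 and compound 2. Because a number 0.7 percentage points higher from compound 1 to compound 2 (within the scatter) stayed within the scatter, compound 4 is expected to give 40% in this assay. The estimated step from compound 3 is a number 0.9 percentage points higher from compound 3 to compound 4 (within the scatter), with an expected range from 31% to 49%.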

Compound 4, a percentage reported as inhibition, in the whole organism at one dose (the size of the read-out at that dose, not a potency): 40.4%
Beside the measured number, compound 4's estimate is 0.4 percentage points below it; the measured number falls inside the stated range.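

In this assay, bromo in place of chloro on an aromatic carbon gave a number 1.3 percentage points higher from compound 3 to compound 4 (within the scatter). Set beside the earlier step, the change reads alike on the core of compound 1 and the core of compound 3: the same change on two cores in this assay, a number 0.7 percentage points higher (within the scatter) from compound 1 to compound 2 and a number 1.3 percentage points higher (within the scatter) from compound 3 to compound 4, 0.6 percentage points apart, within the scatter of two such steps This shows only that the swap left no readable mark on either core; with both steps inside the scatter, it does not show that a change with a real effect would carry from one core to the other.

The compounds shown hold only 4-chlorophenyl and 4-bromophenyl at this place. Going by these compounds, how an amine or a methoxy group there would read on either core stays open, as does a carboxylic acid in place of the ester.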